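The source may report more compounds than this note shows. Statements on the series, on what has been measured and on what is new or still open speak of the compounds shown alone.

In a functional assay on MCF7 cells (Homo sapiens) for inhibition, read by sulforhodamine B assay; on this read-out lower numbers stand for stronger inhibition and higher numbers for weaker inhibition:
- compound 1 `CCc1ccc(NC2=CC(=O)c3nc4n(c3C2=O)[C@H]2OC[C@@H](O)[C@H]2OC4)cc1`: 960 nM
- compound 2 `Cc1ccc(NC2=CC(=O)c3nc4n(c3C2=O)[C@H]2OC[C@@H](O)[C@H]2OC4)cc1C`: 2080 nM

Of the two measured compounds, compound 2 has the higher number, 2080 nM. Compound 3 `O=C1C=C(Nc2cccc(Cl)c2)C(=O)c2c1nc1n2[C@H]2OC[C@@H](O)[C@H]2OC1` differs from it as follows: 3-chlorophenyl in place of 3,4-dimethylphenyl on an amine nitrogen, with 3-chlorophenyl in place of 3,4-dimethylphenyl on an amine nitrogen. Among the measured compounds shown here, only one measured step bears on this exchange: a 2.2-fold higher number from compound 1 to compound 2 (0.34 log units; beyond the scatter), a modest change at the same place. For the measured compounds named here, no measured compound carries the 3-chlorophenyl group, so in this assay no step beyond the scatter is expected, with a slight lean towards a lower number. The estimate amounts to a 1.4-fold lower number from compound 2 to compound 3 (0.14 log units; within the scatter). For compound 3 the expected value is 1500 nM, with an estimated range of 600 nM to 3800 nM.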

Compound 3, half-maximal inhibitory concentration: 4720 nM
Beside the measured number, compound 3's estimate is 3.1-fold (0.50 log units) below it; measured number outside the range, above it.
By their numbers in this assay, from the lowest: compound 1; then compound 2; then compound 3.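

In this assay, a 2.3-fold higher number from compound 2 to compound 3 (0.36 log units; beyond the scatter) and a 4.9-fold higher number from compound 1 to compound 3 (0.69 log units; beyond the scatter) both lie beyond the scatter, so the aryl group on the amine nitrogen still changes the number when the alkyl groups give way to chlorine. Among the three compounds, 3-chlorophenyl carries the highest number, after 3,4-dimethylphenyl and 4-ethylphenyl. Nothing available accounts for this order.

Going by these compounds, whether the higher number follows the chlorine itself or its place on the ring stays open. A 4-chlorophenyl or a methoxyphenyl group on the same nitrogen would help separate the two.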